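Shifting a Fluorine on the Sulfonyl Phenyl Ring

This account rests on a few compounds, and the source may have more. Where it says the series, first, only, none or still open, it means among the compounds named here.

Compounds measured so far in an assay on isolated protein for inhibition of malate dehydrogenase, mitochondrial (Sus scrofa), with stated times of 45 min and 30 min; a higher number here means a weaker inhibitor, a lower number a stronger inhibitor:
Compound 1, `O=S(=O)(Nc1ccc(-c2nc3ccccc3o2)cc1)c1ccccc1O`, gives > 63000 nM, which is a limit of the assay rather than a number.
Compound 2, `O=S(=O)(Nc1ccc(-c2nc3ccccc3o2)cc1)c1ccc(Cl)s1`, gives > 63000 nM, again a limit.
Compound 3, `O=S(=O)(Nc1ccc(-c2nc3ccccc3o2)cc1)c1ccccc1F`, gives > 63000 nM, also a limit.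

Compound 3 therefore stands at the same limit as every other compound here; none of the three has a readable number, as the limit of > 63000 nM in this assay, at which 3 of the 3 values shown sit, records. The steps a step that the two limits leave unreadable from compound 1 to compound 2, a step that the two limits leave unreadable from compound 1 to compound 3 and a step that the two limits leave unreadable from compound 2 to compound 3 are each unreadable for this reason, so no measured step gives a size to work from.

Compound 4, `O=S(=O)(Nc1ccc(-c2nc3ccccc3o2)cc1)c1ccc(F)cc1`, differs from compound 3 only in the change (4-fluorophenyl in place of 2-fluorophenyl on a sulfonyl sulfur). Since the three measured compounds, including compound 3, all sit at the limit, the expected step that the limit leaves unreadable from compound 3 to compound 4 is simply that compound 4 remains at or beyond that limit, with no direction or size beyond the scatter readable. The estimate for compound 4 in this assay is 100000 nM, within 30000 nM to 400000 nM, and most likely reported as a limit only.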

Compound 4, half-maximal inhibitory concentration: > 63000 nM
Compound 4 ended at the assay's limit (the forecaster's own chance of this, stated with the estimate: 85%); the middle value lies beyond the limit too.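

Going by these compounds alone, no step among compound 1, compound 2, compound 3 and compound 4 can be read in this assay since all four stop at the same limit: the limit of > 63000 nM in this assay, at which 4 of the 4 values shown sit.

The compounds shown leave open whether any group on the sulfonyl sulfur gives a readable value, and whether 4-fluorophenyl and 2-fluorophenyl differ at all.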